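Homologating a Ring Hydroxyl in a Spirocyclic Amide Series

This account rests on a few compounds, and the source may have more. Where it says the series, first, only, none or still open, it means among the compounds named here.

Compound 1, `CC(C)(C)OC(=O)NCCCNC(=O)CN1CN(c2ccccc2)C2(CCN(C(=O)c3ccc(C(C)(C)C)cc3)CC2)C1=O`: 4500 nM
Compound 2, `CC(C)(C)c1ccc(C(=O)N2CCC3(CC2)C(=O)N(CC(=O)N2CCCC(O)C2)CN3c2ccccc2)cc1`: 12200 nM

Among the measured compounds shown here, in an assay on HEK293 cells for displacement of a labelled ligand from NPC1-like intracellular cholesterol transporter 1 (Homo sapiens) (on this read-out higher numbers stand for weaker inhibition and lower numbers for stronger inhibition), compound 2 gives 12200 nM, the higher of the two numbers measured so far. Its nearest neighbour is compound 1, which in this assay gives 4500 nM. For the measured compounds named here, the single measured step, a 2.7-fold higher number from compound 1 to compound 2 (0.43 log units; beyond the scatter), concerns a replacement on the amide carbonyl and not the ring substituent itself, so it does not speak directly to the change considered here.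

Compound 3, `CC(C)(C)c1ccc(C(=O)N2CCC3(CC2)C(=O)N(CC(=O)N2CCCC(CO)C2)CN3c2ccccc2)cc1`, differs from compound 2 by hydroxymethyl in place of hydroxy on a saturated ring carbon. Going by the values given here, no measured pair shows what this exchange does in this assay, so the expectation rests on the general smallness of such a change. Compound 3 is therefore expected to give roughly 10000 nM, with a plausible range from 4000 nM to 30000 nM. The step this estimate implies, a 1.2-fold lower number from compound 2 to compound 3 (0.09 log units; within the scatter), is expected to fall within the usual scatter.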

Compound 3, half-maximal inhibitory concentration: 8200 nM
Estimate against measurement, compound 3: 1.2-fold (0.09 log units) above; the range from low to high includes it.
By their numbers in this assay, from the lowest: compounds 1, 3 and 2 (each within the scatter of the next, the first and the last beyond it).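

In this assay, hydroxymethyl in place of hydroxy on this saturated ring carbon gives a 1.5-fold lower number from compound 2 to compound 3 (0.17 log units; within the scatter) and so adds a carbon at this position with no shift that can be told from the scatter. Replacing (3-((tert-butoxycarbonyl)amino)propyl)amino with 3-(hydroxymethyl)piperidin-1-yl on the carbonyl carbon gives a 1.8-fold higher number from compound 1 to compound 3 (0.26 log units; within the scatter) and thus leaves compound 3 within the scatter of both compound 1 and compound 2, although those two lie beyond the scatter of each other. Nothing available explains either step.

As far as these compounds go, whether a longer chain such as 2-hydroxyethyl, or an amine or a carboxylic acid, would stay within this range on the same ring carbon remains open. So does whether any group there could bring the number clearly below that of compound 1.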